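The compounds below may be only part of what the source reports. "The series", "measured", "known", "first", "only" and "open" are said of these compounds alone.

Measured compounds:
compound 1, `CC1CCN(C2CCN(S(=O)(=O)c3cccc(C(F)(F)F)c3)CC2)CC1` — in a functional assay on DLD-1 cells (Homo sapiens) for antiproliferative activity, read by CellTiter-Glo, with a stated time of 72 h; on this read-out lower numbers stand for stronger inhibition and higher numbers for weaker inhibition: > 5000 nM
compound 2, `Cc1cc(C)c(S(=O)(=O)N2CCC(c3ccccc3)CC2)c(C)c1` — in this assay: > 5000 nM

The value given for compound 1 in this assay is a limit of the assay and not a number. Likewise the value for compound 2 in this assay is a limit, so compound 2 stands at the edge of what this assay reports, together with the limit of > 5000 nM in this assay, at which 2 of the 2 values shown sit. No step between measured compounds is shown here; the two values say only that neither compound reached a measurable inhibition.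

Compound 3, `Cc1cc(C)c(S(=O)(=O)N2CCC(N3CCC(C(C)C)CC3)CC2)c(C)c1`, has not been measured in this assay. It differs from compound 2 by 4-isopropylpiperidin-1-yl in place of phenyl on a saturated ring carbon. Compound 3 thus joins the sulfonyl-bearing aryl of compound 2 with a substituted piperidinyl group of the kind seen in compound 1. The step from compound 2 to compound 3 is expected to be a step that the limit leaves unreadable from compound 2 to compound 3, most likely none beyond the scatter. For compound 3 in this assay the estimate is 6000 nM, within 1500 nM to 20000 nM, with a real chance that only a limit is reported.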

Compound 3, half-maximal inhibitory concentration: 0.3 nM
Compound 3: middle estimate off by 20000-fold (4.30 log units), on the high side, outside the stated range (below it).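

In this assay this place, on a saturated ring carbon three ring bonds from the ring nitrogen, proves decisive: 4-isopropylpiperidin-1-yl in place of phenyl brings an at least 16000-fold lower number from compound 2 to compound 3 (4.22 log units; beyond the scatter) in this one change. The earlier compounds gave no measurable number, so compound 3 is the first compound shown to reach one, and it does so with the same sulfonyl-bearing aryl as compound 2. From the compounds shown here alone, the value of compound 2 is a limit and not a number, so the full size of the step stays unknown: the limit of > 5000 nM in this assay, at which 2 of the 3 values shown sit.

The compounds shown leave open whether the isopropyl group or the piperidine nitrogen carries the gain. They also leave open whether a tert-butyl group on that piperidine, or a morpholin-4-yl group or primary amine in its place, would hold this potency.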